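Series notes: the step from compound 3 to compound 4

The source may report more compounds than this note shows. Statements on the series, on what has been measured and on what is new or still open speak of the compounds shown alone.

Compound 1 `Cc1cc(C)nc(Oc2ccc(NC(=O)Nc3ccccc3)cc2)n1` has "not determined" (no result reported) in a functional assay on CNE-2 cells (Homo sapiens) for cytotoxicity, read by MTT assay, with a stated time of 3 days; on this read-out higher numbers stand for weaker inhibition and lower numbers for stronger inhibition. Compound 2 `Cc1cc(C)nc(Oc2ccc(NC(=O)Nc3ccc(F)cc3)cc2)n1` gives 46900 nM in this assay, and compound 3 `Cc1cc(C)nc(Oc2ccc(NC(=O)Nc3ccc(Cl)cc3)cc2)n1` gives 20400 nM. Among the measured compounds shown here, compound 3 stands lowest of the two numbers; the only measured step is a 2.3-fold lower number from compound 2 to compound 3 (0.36 log units; beyond the scatter), a modest one. Compound 4 `Cc1cc(C)nc(Oc2ccc(NC(=O)Nc3ccc(Cl)cc3Cl)cc2)n1` differs from compound 3 by chloro in place of hydrogen on an aromatic carbon. For the measured compounds named here, only that one step bears on this change, and it concerned a chloro replacing fluoro; no measured pair shows chloro entering in place of hydrogen, so the expectation rests on it loosely. A modest lowering in this assay is therefore expected, or none beyond the scatter. For compound 4 the estimated value is 12000 nM, range 4000 nM to 40000 nM. This means an expected step of a 1.7-fold lower number from compound 3 to compound 4 (0.23 log units; within the scatter).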

Compound 4, half-maximal inhibitory concentration: 38900 nM
Compound 4: the middle estimate sits 3.2-fold (0.51 log units) below what was measured; measured number inside the range.
By their numbers in this assay, from the lowest: compounds 3, 4 and 2 (each within the scatter of the next, the first and the last beyond it).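

In this assay, among the compounds shown here, a second chloro ortho to a large group, turning 4-chlorophenyl into 2,4-dichlorophenyl, gives the first reading at this position: the step of a 1.9-fold higher number from compound 3 to compound 4 (0.28 log units; within the scatter) does not extend the lowering seen with chloro in place of fluoro. The step of a 1.2-fold lower number from compound 2 to compound 4 (0.08 log units; within the scatter) likewise leaves 2,4-dichlorophenyl and 4-fluorophenyl unseparated. No other data bear on this result.

As far as these compounds go, whether a methoxy or an amine at this position would read differently from chloro stays open. So does the reading of a chloro here without the second chloro group.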